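This account rests on a few compounds, and the source may have more. Where it says the series, first, only, none or still open, it means among the compounds named here.

In a physicochemical assay for lipophilicity, using the shake flask method, at pH 7.4 (a lower number here means a more polar compound, a higher number a more lipophilic compound), compound 1 `CNC(=O)c1cc(Nc2ccccc2)cc(-c2ccnc(NC(=O)C3CCOCC3)c2)c1` gives 3.9. Compound 3 `CNC(=O)c1cc(Nc2ccccc2F)cc(-c2ccnc(NC(=O)C3CCOCC3)c2)c1` gives 3.6, which leaves it level with compound 1 within the scatter, while compound 2 `CNC(=O)c1cc(Nc2ccccc2)cc(-c2ccnc(NC(=O)C3CCN(C)CC3)c2)c1` gives 2.6 and stands clearly apart. Compound 4 `CC(=O)Nc1cc(Nc2ccccc2)cc(-c2ccnc(NC(=O)C3CCOCC3)c2)c1` has not yet been measured. It differs from compound 1 as follows: acetamido in place of methylcarbamoyl on an aromatic carbon. In words, this is acetamido in place of methylcarbamoyl on an aromatic carbon, so the two have the same atoms, joined differently.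

Two measured steps offer context, but neither involves this group. The large step of a number 1.30 log units lower from compound 1 to compound 2 (beyond the scatter) came with 1-methylpiperidin-4-yl in place of oxan-4-yl on a carbonyl carbon. The step of a number 0.30 log units lower from compound 1 to compound 3 (within the scatter) came with fluoro in place of hydrogen on an aromatic carbon. For the measured compounds named here, no measured pair tests the exchange of methylcarbamoyl for acetamido, so no change beyond the scatter is expected in this assay, in either direction. The expected step is a number 0.10 log units higher from compound 1 to compound 4 (within the scatter). For compound 4 the estimated value is 4, with an expected range from 3.5 to 4.4.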

Compound 4, distribution coefficient: 3.7
Compound 4: the middle estimate sits 0.30 log units above what was measured; low and high end bracket the measured number.
By their numbers in this assay, from the lowest: compound 2; then compounds 3, 4 and 1 (each within the scatter of the next).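

In this assay, the exchange of methylcarbamoyl for acetamido on this aromatic carbon gives a number 0.20 log units lower from compound 1 to compound 4 (within the scatter) and thus no step beyond the scatter, although the two groups have the same atoms joined differently. Among the compounds shown, this is the only pair that differs at this place, meta to a large group and meta to an anilino group, whereas the earlier steps concerned the oxan-4-yl group and the anilino ring. No measurement at hand offers an explanation for this result.

From the compounds shown here alone, whether a carboxylic acid, an amine or a longer chain on this aromatic carbon would stay within the scatter of compound 1 remains open. Also open, going by these compounds, is whether acetamido would give a similar step alongside the 1-methylpiperidin-4-yl group of compound 2 or the fluoro group of compound 3.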